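The source may report more compounds than this note shows. Statements on the series, on what has been measured and on what is new or still open speak of the compounds shown alone.

Measured compounds in an assay on isolated protein for inhibition of Amine oxidase [flavin-containing] B (Homo sapiens), read by fluorescence and Amplex Red, with stated times of 15 min and 20 min; on this read-out higher numbers stand for weaker inhibition and lower numbers for stronger inhibition:
- compound 1, `Cc1ccc(/C=N/c2ccc(OCc3ccccc3)cc2)c(O)c1`, 24400 nM
- compound 2, `Oc1ccc(/C=N/c2ccc(OCc3ccccc3)cc2)c(O)c1O`, 1730 nM
- compound 3, `Oc1cc(O)c(/C=N/c2ccc(OCc3ccccc3)cc2)c(O)c1`, 10100 nM

Three imines built on the same benzyloxy-substituted aniline have been tested in this assay, and compound 2 gives the lowest half-maximal inhibitory concentration of the three. Compound 3 stands next to it, with a higher number, and compound 1 is the furthest from it; both gaps lie beyond the usual scatter of this measurement, so compound 2 can be called the strongest inhibitor among the three measured.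

The step to compound 4, `Oc1cccc(/C=N/c2ccc(OCc3ccccc3)cc2)c1O`, changes compound 2 in one place: hydrogen in place of hydroxy on an aromatic carbon. Nothing else is altered.

Among the measured compounds shown here, no step of this kind has yet been measured, so the expected size must be judged from the three values alone. Compound 1 and compound 3, which carry different patterns of hydroxy groups on the aldehyde-derived ring, both give weaker inhibition than compound 2, and compound 4 carries one hydroxy fewer than compound 2. The step of a 2.9-fold higher number from compound 2 to compound 4 (0.46 log units; beyond the scatter) is therefore expected to go toward weaker inhibition, by a modest amount that may exceed the scatter. Compound 4 is estimated at 5000 nM, within a range of 1500 nM to 16000 nM.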

Compound 4, half-maximal inhibitory concentration: 6870 nM
For compound 4 the middle estimate is 1.4-fold (0.14 log units) below the measured one, and the stated range covers the measured number.
By their numbers in this assay, from the lowest: compound 2; then compounds 4 and 3 (each within the scatter of the next); then compound 1.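

Within this assay this is the first step in the series that changes a single place, and it shows that the hydroxy group ortho to a hydroxy group, meta to a hydroxy group and para to a large group counts for inhibition: hydrogen in its place gives a 4.0-fold higher number from compound 2 to compound 4 (0.60 log units; beyond the scatter) and so a modest loss beyond the scatter. The loss is only partial, since the 2,3-dihydroxyphenyl of compound 4 in place of the 2-hydroxy-4-methylphenyl of compound 1 still corresponds to a 3.6-fold lower number from compound 1 to compound 4 (0.55 log units; beyond the scatter) on the same read-out, so the remaining pair of hydroxy groups keeps an advantage over that hydroxy and methyl pattern. Nothing at hand explains why this hydroxy group affects the read-out.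

The compounds shown leave open whether a methoxy group, an amine or a fluorine atom at this same carbon would match the hydroxy group of compound 2 or behave like the hydrogen of compound 4. They also leave open whether the size of this step would hold if the benzyloxy part of the core carried a chlorine atom or gave way to a longer chain.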